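The source may hold more compounds than are shown below. What is called first, only, known or untested is meant among the compounds shown, and "the series" means these compounds.

The compounds measured so far in an assay on HEK293 cells for displacement of a labelled ligand from Neuronal acetylcholine receptor; alpha3/beta4 (Homo sapiens), read by scintillation counting, with a stated time of 120 min; a lower number here means a stronger inhibitor, a higher number a weaker inhibitor:
compound 1, `Oc1ccc(-c2cn([C@H]3CN4CCC3CC4)nn2)cc1`, 138 nM
compound 2, `Fc1ccc(-c2cn([C@H]3CN4CCC3CC4)nn2)cc1`, 1010 nM
compound 3, `Fc1cccc(-c2cn([C@H]3CN4CCC3CC4)nn2)c1`, 362 nM

Compound 1 gives the lowest number of the three. Compound 3 is nearest to it, and its value of 362 nM lies above that of compound 1 by more than the scatter. Compound 2 is furthest away: a 7.3-fold higher number from compound 1 to compound 2 (0.86 log units; beyond the scatter).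

The move from compound 1 to compound 4, `Oc1ccc(-c2cn(C3CN4CCC3CC4)nn2)cc1`, is of a different kind: the two compounds have the same atoms and bonds; at least one stereo element is drawn with a configuration in one of them and without one in the other: 1 of 3 stereo elements differ; a stereocentre at a saturated ring carbon is drawn R in compound 1 and without a configuration in compound 4. Every atom and bond is kept; what is absent in compound 4 is only the drawn configuration at that saturated ring carbon. For the measured compounds named here, no measured step speaks to this. The step from compound 1 to compound 2 and the gap between compound 1 and compound 3 both replace a group on an aromatic carbon, while all three measured compounds carry the same drawn configuration at the ring carbon. With no measured guide, the expected step from compound 1 to compound 4 in this assay is a small one, a 1.4-fold higher number from compound 1 to compound 4 (0.16 log units; within the scatter), with a slight weakening thought somewhat more likely than a strengthening. Compound 4 is estimated at 200 nM, within a range of 100 nM to 500 nM.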

Compound 4, inhibition constant: 3.44 nM
Estimate against measurement, compound 4: 58-fold (1.76 log units) above; the whole stated range lies above it.
By their numbers in this assay, from the lowest: compound 4; then compound 1; then compound 3; then compound 2.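

In this assay, for the compounds shown here, the earlier compounds showed only what a change of group on an aromatic carbon does, whereas here the structure stays the same apart from how one saturated ring carbon is drawn, and the result is a 40-fold lower number from compound 1 to compound 4 (1.60 log units; beyond the scatter). That is a larger step than the swap of hydroxy for fluoro, a 7.3-fold higher number from compound 1 to compound 2 (0.86 log units; beyond the scatter), so the configuration at this carbon can matter more than the group on the aromatic ring. A drawing without a configuration may stand for a mixture of both forms or for a single unassigned form, and if compound 4 contains the form drawn in compound 1, its stronger binding would have to come from the opposite form; the only structural difference that can be pointed to for this gap is: the fact that one of compounds 1 and 4 is drawn with a defined configuration and the other without, at the place where they differ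

On these data alone, what compound 4 actually contains remains open, as does the number that a pure sample of the opposite configuration would give. Also open, as far as these compounds go, is whether the same gap would appear with the fluoro groups of compound 2 and compound 3, or with a methoxy group or an amine in place of the hydroxy.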